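Three Flat Results Point to a Fourth

The source may hold more compounds than are shown below. What is called first, only, known or untested is meant among the compounds shown, and "the series" means these compounds.

Measured so far:
compound 1, `CC(C)(C)Cc1csc(N)c1C(=O)c1ccc(Cl)c(Cl)c1`, in an assay on CHO cells for displacement of a labelled ligand from adenosine receptor A1 (Homo sapiens), read by scintillation counting, tested at 10 uM (a higher number here means more inhibition at the concentration tested (going by the name of the read-out), a lower number less inhibition), gives 1%
compound 2, `CC(C)(C)Cc1c(Br)sc(N)c1C(=O)c1ccc(Cl)c(Cl)c1`, in this assay gives 1%
compound 3, `CC(C)(C)Cc1c(-c2ccccc2)sc(N)c1C(=O)c1ccccc1Cl`, in this assay gives 1%

Compound 3 stands level with compounds 1 and 2; its nearest neighbour on these numbers is compound 1 and its furthest is compound 2, and both gaps lie within the scatter. The next compound, compound 4, `CC(C)(C)Cc1c(-c2ccccc2)sc(N)c1C(=O)c1ccc(Cl)c(Cl)c1`, differs from compound 3 in one place: 3,4-dichlorophenyl in place of 2-chlorophenyl on a carbonyl carbon.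

Going by the values given here, no measured step changes the group on the carbonyl carbon directly. Among the compounds with values here, the one measured step, no change at the digits printed from compound 1 to compound 2 (within the scatter), concerns a bromo in place of hydrogen on an aromatic carbon and shows nothing beyond the scatter. What bears on compound 4 instead is that compound 1 already carries 3,4-dichlorophenyl on the carbonyl carbon and compound 3 carries 2-chlorophenyl there, and their values are within the scatter of each other. Compound 4 therefore is expected to show no step beyond the scatter, no change at the digits printed from compound 3 to compound 4 (within the scatter). For compound 4 the estimate in this assay is 1%, with a range from -9% to 11%.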

Compound 4, a percentage reported as inhibition, at one concentration (the size of the read-out at that concentration, not a potency): 1%
Compound 4: middle estimate and measured number agree at the digits printed; the measured number falls inside the stated range.
By their numbers in this assay, from the lowest: compounds 1, 2, 3 and 4 (each within the scatter of the next).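

In this assay, the group on the carbonyl carbon has now been changed directly, with the rest of the molecule held constant, and the result is no change at the digits printed from compound 3 to compound 4 (within the scatter) for 3,4-dichlorophenyl in place of 2-chlorophenyl. The aromatic carbon that first held hydrogen and then bromo can now be read with a larger group as well: phenyl in place of bromo gives no change at the digits printed from compound 2 to compound 4 (within the scatter) as its result, and phenyl in place of hydrogen gives no change at the digits printed from compound 1 to compound 4 (within the scatter) as its result. Across these four compounds, then, neither the chlorine pattern on the carbonyl-bound phenyl nor the choice of hydrogen, bromo or phenyl on the aromatic carbon separates the values, and nothing available here explains why they sit together.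

The compounds shown leave open whether an amine or a carboxylic acid on that aromatic carbon, or a methoxy group or a nitrile on the phenyl at the carbonyl carbon, would give a different reading. They also leave open what a longer chain or a different group in place of the shared 2,2-dimethylpropyl chain would do.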